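This account rests on a few compounds, and the source may have more. Where it says the series, first, only, none or still open, it means among the compounds named here.

Of the compounds shown here, three sharing one core have been measured in a functional assay (trachea) with Cavia porcellus as the target (a lower number here means that less compound is needed, a higher number that more compound is needed for the effect), so far. Compound 1 `CCCn1c(=O)n(CC)c(=O)c2[nH]cnc21` gives 1300 nM and compound 2 `CCCn1c(=O)n(CCC#N)c(=O)c2[nH]cnc21` gives 1700 nM in this test, while compound 3 `CCCn1c(=O)n(CCO)c(=O)c2[nH]cnc21` gives 510 nM as the lowest number of the three. The cyano step (a 1.3-fold higher number from compound 1 to compound 2 (0.12 log units; within the scatter)) stays within the scatter. The hydroxy steps are modest but beyond it (a 2.5-fold lower number from compound 1 to compound 3 (0.41 log units; beyond the scatter); a 3.3-fold lower number from compound 2 to compound 3 (0.52 log units; beyond the scatter)). Compound 4 `CCCn1c(=O)n(CCOCC)c(=O)c2[nH]cnc21` takes the story further, with ethyl in place of hydrogen on an oxygen on a saturated carbon, so that 2-hydroxyethyl becomes 2-ethoxyethyl (ethyl in place of hydrogen on an oxygen on a saturated carbon). Among the measured compounds shown here, no measured step changes this oxygen directly, so the hydroxy steps are the closest guide, and the ethoxy group no longer carries that hydroxy. A modest move to a higher number in this assay is therefore expected, back toward the other two compounds, as an estimated step (a 2.2-fold higher number from compound 3 to compound 4 (0.33 log units; beyond the scatter)) of uncertain size. The estimate for compound 4 is 1100 nM (range 400 nM to 2800 nM).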

Compound 4, half-maximal effective concentration: 70 nM
Compound 4: middle estimate off by 16-fold (1.20 log units), on the high side, and the stated range ends above it.
By their numbers in this assay, from the lowest: compound 4; then compound 3; then compounds 1 and 2 (each within the scatter of the next).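

In this assay, ethyl on the oxygen of the 2-hydroxyethyl chain does not undo the hydroxy gain but goes well past it (a 7.3-fold lower number from compound 3 to compound 4 (0.86 log units; beyond the scatter)), so at this position a free hydroxy hydrogen is not required for a low number. The position proves far more responsive than the first three compounds suggested: the 2-ethoxyethyl chain stands clear of both the ethyl chain (a 19-fold lower number from compound 1 to compound 4 (1.27 log units; beyond the scatter)) and the 2-cyanoethyl chain (a 24-fold lower number from compound 2 to compound 4 (1.39 log units; beyond the scatter)), and these two steps are the only large ones so far. Nothing available accounts for this change in the number.

The compounds shown cannot separate the contribution of the ethyl group from that of the chain oxygen. From the compounds shown here alone, how methoxy, a longer chain on that oxygen or an amine in place of ethoxy would behave also remains open.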